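Replacing formyl with 2-(ethoxycarbonyl)ethenyl: compound 3 to compound 4

The compounds below may be only part of what the source reports. "The series", "measured", "known", "first", "only" and "open" are said of these compounds alone.

Of the compounds shown here, three have been tested so far in a functional assay on SEM cells (Homo sapiens) for cytotoxicity, with a stated time of 72 h; on this read-out lower numbers stand for an effect already at smaller amounts and higher numbers for an effect only at larger amounts of compound. Compound 1 (`C=C[C@@](C)(/C=C/c1ccc(OS(=O)(=O)C(F)(F)F)cc1)CCC=C(C)C`) gives > 36600 nM, which is a limit of the assay and not a number. Compound 2 (`C=C[C@@](C)(/C=C/c1ccc(O)cc1)CC/C=C/C(=O)OCC`) gives > 36600 nM, again only a limit. Among the compounds with values here, compound 3 (`C=C[C@@](C)(/C=C/c1ccc(O)c(C=O)c1)CCC=C(C)C`) is the only one with a measured number in this assay, at 8510 nM.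

Compound 4 (`C=C[C@@](C)(/C=C/c1ccc(O)c(/C=C/C(=O)OCC)c1)CCC=C(C)C`) keeps the core of compound 3 and carries 2-(ethoxycarbonyl)ethenyl in place of formyl on an aromatic carbon, ortho to a hydroxy group (2-(ethoxycarbonyl)ethenyl in place of formyl on an aromatic carbon). Within the data shown here, no measured pair differs in one place, so the expectation rests on compound 3 at 8510 nM alone. The expected change is small, with the estimated step of a 1.2-fold higher number from compound 3 to compound 4 (0.07 log units; within the scatter) leaning slightly towards higher numbers and staying within the usual scatter. A result reported only as a limit remains possible. The estimate for compound 4 is 10000 nM, with an expected range of 3500 nM to 30000 nM.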

Compound 4, half-maximal effective concentration: > 36600 nM
Compound 4 gave a limit, no number (the forecaster's own chance of this, stated with the estimate: 25%); at least 3.6-fold (0.56 log units) between middle value and limit.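

In this assay, the aromatic carbon ortho to a hydroxy group proves sensitive to the group it carries: 2-(ethoxycarbonyl)ethenyl in place of formyl gives an at least 4.3-fold higher number from compound 3 to compound 4 (0.63 log units; beyond the scatter). Within the data shown here, this is the first comparison that changes one place only, and it ties the single measured number of the series to the formyl-bearing compound 3 rather than to the shared core alone. Compound 4 gives > 36600 nM, which is a limit of the assay and not a number, and the full size of the step stays unknown, as the read-out ends at one value: the limit of > 36600 nM in this assay, at which 3 of the 4 values shown sit.

Still open, as far as these compounds go, is whether the change in the number follows the longer group as a whole, its ethyl ester or its added double bond. A carboxylic acid in place of the ester, or a hydroxymethyl or aminomethyl group at this carbon, would help separate these readings.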